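The compounds below may be only part of what the source reports. "The series", "measured", "known", "first", "only" and "open" are said of these compounds alone.

Measured in a functional assay on SMMC-7721 cells (Homo sapiens) for antiproliferative activity, read by MTT assay, with a stated time of 48 h; on this read-out lower numbers stand for stronger inhibition and higher numbers for weaker inhibition:
- compound 1 `CC(C)=CCC[C@]1(C)/C=C/[C@@H](OC(=O)C=C(C)C)[C@](C)(O)/C=C/C(=O)/C(C(=O)O)=C\C1`: > 10000 nM (a limit)
- compound 2 `CC(C)=CCC[C@]1(C)/C=C/[C@@H](OC(=O)C=C(C)C)[C@](C)(O)/C=C/C(=O)/C(CCl)=C\C1`: 840 nM
- compound 3 `CC(C)=CCC[C@]1(C)/C=C/[C@@H](OC(=O)C=C(C)C)[C@](C)(O)/C=C/C(=O)/C(CN2CCN(C)CC2)=C\C1`: 2940 nM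

Of the two actual numbers, compound 3 holds the higher, and compound 2 is its nearest neighbour. Compound 4 `CC[Si](CC)(CC)C/C1=C/C[C@](C)(CCC=C(C)C)/C=C/[C@@H](OC(=O)C=C(C)C)[C@](C)(O)/C=C/C1=O` is the next to be read. The change is a group of 7 heavy atoms (6 carbon, 1 silicon; no ring) in place of a group of 7 heavy atoms (5 carbon, 2 nitrogen; one six-membered non-aromatic ring with 2 hetero atoms), on a saturated chain carbon bound to a double-bonded ring carbon, on a saturated chain carbon bound to a double-bonded ring carbon. Within the data shown here, the closest precedent, at this same carbon, is a 3.5-fold higher number from compound 2 to compound 3 (0.54 log units; beyond the scatter). Replacing carboxy gave an at least 11-fold lower number from compound 1 to compound 2 (1.07 log units; beyond the scatter) and an at least 3.4-fold lower number from compound 1 to compound 3 (0.53 log units; beyond the scatter), but these start from a limit and bear less directly. Among the measured compounds shown here, the entering group has no measured precedent, so only a small shift toward stronger inhibition is expected: a 1.6-fold lower number from compound 3 to compound 4 (0.21 log units; within the scatter). The estimate for compound 4 is 1800 nM, with an expected range from 500 nM to 7000 nM.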

Compound 4, half-maximal inhibitory concentration: 3460 nM
Compound 4: the middle estimate sits 1.9-fold (0.28 log units) below what was measured, and the stated range covers the measured number.
By their numbers in this assay, from the lowest: compound 2; then compounds 3 and 4 (each within the scatter of the next). At a limit, above all of these: compound 1.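

At this saturated chain carbon, the silicon-bearing group with no ring does not separate from 4-methylpiperazin-1-yl (a 1.2-fold higher number from compound 3 to compound 4 (0.07 log units; within the scatter)), so neither that ring nor its nitrogens are needed to hold this level. Both groups of 7 heavy atoms now stand on the weaker side of chloro (a 3.5-fold higher number from compound 2 to compound 3 (0.54 log units; beyond the scatter); a 4.1-fold higher number from compound 2 to compound 4 (0.61 log units; beyond the scatter)). The step from the carboxy compound starts at a limit and reads only as a bound (an at least 2.8-fold lower number from compound 1 to compound 4 (0.46 log units; beyond the scatter)): the limit of > 10000 nM in this assay, at which 1 of the 4 values shown sits.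

On these data alone, whether a bromine atom or a dimethylamino group at this carbon would stand with chloro or with the two larger groups stays open.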